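Methoxy to ethoxy on the shared core: aorta series notes

The source may report more compounds than this note shows. Statements on the series, on what has been measured and on what is new or still open speak of the compounds shown alone.

Compound 1 `COc1ccc(-c2cc(-c3cc4ccccc4o3)nc(OC)c2C#N)c(OC)c1` gives 425000 nM in a functional assay on aorta (strain Wistar) for inhibition, with Thoracic aorta (Rattus norvegicus) as the target; a lower number here means a stronger inhibitor, a higher number a weaker inhibitor. Compound 2 `CCOc1nc(-c2cc3ccccc3o2)cc(-c2ccc(OC)cc2OC)c1C#N` differs from compound 1 by methyl in place of hydrogen on a saturated chain carbon bound to an oxygen on an aromatic ring; compound 2 gives 488000 nM in this assay, and the step is a 1.1-fold higher number from compound 1 to compound 2 (0.06 log units; within the scatter). Compound 3 `COc1cc(-c2cc(-c3cc4ccccc4o3)nc(OC)c2C#N)cc(OC)c1OC` carries a different aryl part; the difference between the core of compound 3 and the core of compound 1 is not broken down here. In this assay compound 3 gives 310000 nM, and its gaps to compound 1 and to compound 2 stay within the scatter, so no order among the three can be read.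

Compound 4 `CCOc1nc(-c2cc3ccccc3o2)cc(-c2cc(OC)c(OC)c(OC)c2)c1C#N` is not yet measured. It differs from compound 3 by methyl in place of hydrogen on a saturated chain carbon bound to an oxygen on an aromatic ring, the same change as from compound 1 to compound 2, at the same place in both cases. Among the measured compounds shown here, the step of a 1.1-fold higher number from compound 3 to compound 4 (0.04 log units; within the scatter) is expected to be small, resting on the one measured example a 1.1-fold higher number from compound 1 to compound 2 (0.06 log units; within the scatter), which sits within the scatter. Compound 4 is therefore estimated at 340000 nM in this assay, with a likely range from 170000 nM to 680000 nM.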

Compound 4, half-maximal inhibitory concentration: 365000 nM
Compound 4: the middle estimate sits 1.1-fold (0.03 log units) below what was measured; the range from low to high includes it.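

The methoxy to ethoxy change gives a 1.2-fold higher number from compound 3 to compound 4 (0.07 log units; within the scatter) in this assay. Set beside the same change on the core of compound 1, this step shows no difference between the two cores: the same change on two cores in this assay, a 1.1-fold higher number (0.06 log units; within the scatter) from compound 1 to compound 2 and a 1.2-fold higher number (0.07 log units; within the scatter) from compound 3 to compound 4, 1.0-fold (0.01 log units) apart, within the scatter of two such steps

Across these two pairs, the change therefore carries from one core to the other with no step beyond the scatter, but neither step can be told apart from the scatter, so no direction can be assigned to the change, and two pairs do not establish how it behaves on any other core.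

The compounds shown hold only methoxy and ethoxy at this place, so a longer chain such as propoxy or butoxy, or an amine in place of the ether oxygen, remains open. Also open, as far as these compounds go, is whether a carboxylic acid on the aryl part would give a step beyond the scatter, or would alter how the methoxy to ethoxy change carries between cores.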